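Shortening the Amide Substituent from Octyl to Isopropyl

A few compounds are considered here, and "the series" means these few. Any claim that something is new, unique, unknown or untested is made for them only; others in the source may bear on it.

Compound 1 `COc1ccc(/C=C/c2cc(OC)cc(OC)c2/C=C/C(=O)Nc2cc(OC)c(OC)c(OC)c2)cc1`: 5140 nM
Compound 2 `CCCCCCCCNC(=O)/C=C/c1c(/C=C/c2ccc(OC)cc2)cc(OC)cc1OC`: 8660 nM

In a functional assay on A549 cells (Homo sapiens) for inhibition, read by MTT assay, with a stated time of 48 h (a lower number here means a stronger inhibitor, a higher number a weaker inhibitor), compound 1 gives 5140 nM and compound 2 gives 8660 nM. On the two numbers shown compound 2 stands at the top, yet the step of a 1.7-fold higher number from compound 1 to compound 2 (0.23 log units; within the scatter) lies within the scatter, so the two are not truly told apart. Compound 3 `COc1ccc(/C=C/c2cc(OC)cc(OC)c2/C=C/C(=O)NC(C)C)cc1` differs from compound 2 by isopropyl in place of octyl on an amide-type nitrogen. Among the compounds with values here, no measured step exchanges one chain for another on this amide-type nitrogen; the one step known, octyl in place of 3,4,5-trimethoxyphenyl, barely moved the number. Compound 3 is therefore expected to give about 9000 nM, between 3500 nM and 25000 nM, which means an expected step of a 1.0-fold higher number from compound 2 to compound 3 (0.02 log units; within the scatter) within the scatter.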

Compound 3, half-maximal inhibitory concentration: 2360 nM
Estimate against measurement, compound 3: 3.8-fold (0.58 log units) above; measured number below the stated range.
By their numbers in this assay, from the lowest: compound 3; then compounds 1 and 2 (each within the scatter of the next).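

Compared with the earlier pair, this result shows that the group on the amide-type nitrogen can matter in this assay: isopropyl in place of octyl gives a 3.7-fold lower number from compound 2 to compound 3 (0.56 log units; beyond the scatter). Isopropyl in place of 3,4,5-trimethoxyphenyl also moves the number, giving a 2.2-fold lower number from compound 1 to compound 3 (0.34 log units; beyond the scatter). Nothing available explains why these changes have this effect.

Three groups cannot establish a trend with chain size. As far as these compounds go, how a methyl group, a butyl chain or a chain ending in a carboxylic acid would compare on this nitrogen remains open.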